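Stability series: removing the ring fluoro from compound 2

The source may hold more compounds than are shown below. What is called first, only, known or untested is meant among the compounds shown, and "the series" means these compounds.

Compound 1 `C=CC(=O)Nc1cc(Nc2ncc(F)c(Nc3ccccc3S(=O)(=O)N(C)C)n2)c(OC)cc1N(C)CCN(C)C` in an ADME assay on microsomes from liver (Mus musculus) for metabolic stability, read by LC-MS, using NADPH, with a stated time of 30 min, tested at 1 uM (on this read-out lower numbers stand for a less stable compound and higher numbers for a more stable compound), gives 10%. Compound 2 `C=CC(=O)Nc1cc(Nc2ncc(F)c(Nc3ccccc3S(=O)(=O)C(C)C)n2)c(OC)cc1N(C)CCN(C)C` gives 15% in this assay, and compound 3 `C=CC(=O)Nc1cc(Nc2ncc(I)c(Nc3ccccc3S(=O)(=O)N(C)C)n2)c(OC)cc1N(C)CCN(C)C` gives 12%. The change a number 5 percentage points higher from compound 1 to compound 2 (within the scatter) and the change a number 2 percentage points higher from compound 1 to compound 3 (within the scatter) both stay inside the scatter, so the three measured compounds stand together and compound 2 cannot be set apart from compound 3 or compound 1 on these numbers.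

Compound 4 `C=CC(=O)Nc1cc(Nc2nccc(Nc3ccccc3S(=O)(=O)C(C)C)n2)c(OC)cc1N(C)CCN(C)C` is not yet measured. It differs from compound 2 by hydrogen in place of fluoro on an aromatic carbon. Among the compounds with values here, the only measured step at this carbon is the one from compound 1 to compound 3, where iodo replaced fluoro and the number stayed within the scatter; no measured pair shows hydrogen replacing fluoro. With a small group leaving from a position whose one probed substitution did not move the number, the step of no change at the digits printed from compound 2 to compound 4 (within the scatter) is expected to remain within the scatter, in no clear direction. Compound 4 is therefore estimated at 15%, with a range from 5% to 30%.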

Compound 4, percent of the compound remaining: 8%
For compound 4 the middle estimate is 7 percentage points above the measured one; low and high end bracket the measured number.
By their numbers in this assay, from the lowest: compounds 4, 1, 3 and 2 (each within the scatter of the next).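

In this assay hydrogen in place of fluoro on this aromatic carbon gives a number 7 percentage points lower from compound 2 to compound 4 (within the scatter) and so the number is not shown to depend on the fluoro. Together with a number 2 percentage points higher from compound 1 to compound 3 (within the scatter) for iodo in place of fluoro, this makes two changes at this carbon that stay inside the scatter, one with isopropyl and one with dimethylamino on the sulfonyl sulfur. No measurement at hand bears on why the step from fluoro to hydrogen comes out as it does.

Open, from the compounds shown here alone, is whether an amine or a nitrile on this carbon would move the number beyond the scatter. Also open, going by these compounds, is whether hydrogen in place of fluoro gives a similar step with dimethylamino on the sulfonyl sulfur.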